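The compounds below may be only part of what the source reports. "The series", "measured", "known", "first", "only" and "open" are said of these compounds alone.

Measured so far:
compound 1 `CSCC[C@H](NC(=O)CN(c1nc(Cl)nc2[nH]cnc12)C1CC1)C(=O)OCc1ccccc1` gives 44.6%
compound 2 `N=C(N)NCCC[C@H](NC(=O)CN(c1nc(Cl)nc2[nH]cnc12)C1CC1)C(=O)OCc1ccccc1` gives 30.4%
compound 3 `O=C(CN(c1nc(Cl)nc2[nH]cnc12)C1CC1)NCC(=O)OCc1ccccc1` gives 27.2%

In a functional assay on the whole organism (Tail, strain ICR) with Mus musculus as the target, in the tail flick test, with a stated time of 90 min, at a dose of 25 umol/kg by the oral route (on this read-out higher numbers stand for a stronger effect at the one dose given and lower numbers for a weaker effect), compound 3 gives the lowest of the three numbers. Compound 2 lies nearby, as a number 3.2 percentage points lower from compound 2 to compound 3 (within the scatter) shows; compound 1 is furthest off, by a number 17.4 percentage points lower from compound 1 to compound 3 (beyond the scatter).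

Compound 4 `NC(=O)C[C@H](NC(=O)CN(c1nc(Cl)nc2[nH]cnc12)C1CC1)C(=O)OCc1ccccc1` is built from compound 3 by carbamoylmethyl in place of hydrogen on a saturated chain carbon bound to an amide-type nitrogen and a carbonyl carbon. Among the measured compounds shown here, two measured steps bear on it: adding 2-(methylsulfanyl)ethyl at this carbon, reversed from a number 17.4 percentage points lower from compound 1 to compound 3 (beyond the scatter), gave a modest rise, while adding the seven-atom group, reversed from a number 3.2 percentage points lower from compound 2 to compound 3 (within the scatter), stayed within the scatter. A third side chain at the same carbon is therefore expected to move this assay only a little upward, if at all, by about a number 3.8 percentage points higher from compound 3 to compound 4 (within the scatter). Compound 4 is estimated at 31%, expected between 18% and 46%.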

Compound 4, a percentage reported as activity, at one dose (the size of the read-out at that dose, not a potency): 32.3%
The estimate for compound 4 lay 1.3 percentage points below the measured number; the measured number falls inside the stated range.
By their numbers in this assay, from the lowest: compounds 3, 2 and 4 (each within the scatter of the next); then compound 1.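

In this assay, carbamoylmethyl on this saturated chain carbon gives a number 5.1 percentage points higher from compound 3 to compound 4 (within the scatter) and so cannot be told apart from plain hydrogen, and a number 1.9 percentage points higher from compound 2 to compound 4 (within the scatter) places it level with the arginine-type side chain of compound 2 as well. Only the side chain of compound 1 stands clear of it, with a number 12.3 percentage points lower from compound 1 to compound 4 (beyond the scatter) as the step, so compound 1 remains alone among the four. No measurement here explains this difference. On these data alone, whether the sulfur matters or the chain alone is enough remains open, and a plain butyl chain would separate the two. A carboxylic acid or a simple amine at this carbon also remains untested among the compounds shown.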